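A Second Methoxy Group Added to Compound 2

A few compounds are considered here, and "the series" means these few. Any claim that something is new, unique, unknown or untested is made for them only; others in the source may bear on it.

Among the measured compounds shown here, compound 2 `COc1ccc(/C=C/C2CC=CC(=O)N2)cc1` is the only member of this small set for which a functional assay on OVCAR-3 cells (Homo sapiens) for inhibition, read by sulforhodamine B assay, with a stated time of 48 h (on this read-out lower numbers stand for stronger inhibition of growth and higher numbers for weaker inhibition of growth), returns a number: compound 2 gives 787 uM. Compound 1 `O=C1C=CCC(/C=C/c2ccccc2)N1`, which carries no methoxy group, stops at a limit of the assay, > 1250 uM. Compound 3 `COc1ccc(/C=C/C2CC=CC(=O)N2)c(OC)c1`, with two methoxy groups, likewise stops at a limit, > 964 uM. The measured steps are therefore small and open-ended: an at least 1.5-fold lower number from compound 1 to compound 2 (0.20 log units; that floor lies within the scatter), and an at least 1.2-fold higher number from compound 2 to compound 3 (0.08 log units; that floor lies within the scatter); because of the limit of > 1250 uM in this assay, at which 1 of the 3 values shown sits, and the limit of > 964 uM in this assay, at which 1 of the 3 values shown sits, neither step can be sized beyond its floor.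

Compound 4 `COc1ccc(/C=C/C2CC=CC(=O)N2)cc1OC` differs from compound 2 by methoxy in place of hydrogen on an aromatic carbon. The step of an at least 1.2-fold higher number from compound 2 to compound 3 (0.08 log units; that floor lies within the scatter) bears most directly on this change, as that step likewise adds a methoxy group on an aromatic carbon of the shared core and ends at a limit. The account therefore expects no step beyond the scatter in this assay, with a lean toward a higher number: a 1.2-fold higher number from compound 2 to compound 4 (0.08 log units; within the scatter). Compound 4 is estimated at 950 uM, within a range from 450 uM to 2000 uM.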

Compound 4, concentration for growth inhibition (reported as GI): > 964 uM
Compound 4 gave a limit, no number; the forecaster's own chance of this, stated with the estimate: 50%; at least 1.0-fold (0.00 log units) between middle value and limit.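

In this assay, among the compounds shown here, methoxy in place of hydrogen ortho to a methoxy group and meta to a group of 9 heavy atoms gives an at least 1.2-fold higher number from compound 2 to compound 4 (0.08 log units; that floor lies within the scatter), so this position, like the one filled in compound 3, shows no step beyond the scatter. For the compounds shown here, compound 4 also stops at a limit, the same one printed for compound 3, which leaves compound 2 the only compound of the dimethoxy comparison with a number. The true size of the step cannot be told because the value of compound 4 is a limit: the limit of > 964 uM in this assay, at which 2 of the 4 values shown sit.

The compounds shown leave open how far the real value of compound 4 lies from that floor. They also leave open what an amine or a carboxylic acid would do at this position in place of the methoxy group.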